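The source may hold more compounds than are shown below. What is called first, only, known or untested is meant among the compounds shown, and "the series" means these compounds.

Measured compounds:
Compound 1 `O=C(O)Cc1sc(Cc2ccccc2)nc1-c1ccc(Cl)cc1`: 50%
Compound 2 `CCC(c1ccccc1)c1nc(-c2ccc(Cl)cc2)c(CC(=O)O)s1`: 50%
Compound 3 `O=C(O)Cc1sc(NCc2ccccc2)nc1-c1ccc(Cl)cc1`: 30%

In an in vitro functional assay on HEK285-7 cells for antagonist activity at prostaglandin D2 receptor 2 (Homo sapiens), read by BRET and beta-arrestin recruitment (a lower number here means a smaller maximal response, a higher number a larger maximal response), compound 2 stands level with compound 1 at the digits shown, and together these two give the highest numbers of the three; compound 3 lies furthest from them. The step of no change at the digits printed from compound 1 to compound 2 (within the scatter) shows that adding a chain carbon at this place left the maximal response where it was, while the step of a number 20 percentage points lower from compound 1 to compound 3 (beyond the scatter) shows a modest fall when the link to the ring was changed.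

Compound 4 `O=C(O)Cc1sc(C(Cc2ccccc2)c2ccccc2)nc1-c1ccc(Cl)cc1` differs from compound 2 in one place: phenyl in place of methyl on a saturated chain carbon, two bonds along the chain from two aromatic carbons. Within the data shown here, only the step from compound 1 to compound 2 bears directly on it, since it also changes the group on the saturated chain carbon bound to two aromatic carbons, and that step stayed within the scatter. Among the measured compounds shown here, no measured step adds a ring at this place, so the expectation rests on a single step. The step of no change at the digits printed from compound 2 to compound 4 (within the scatter) is therefore estimated as none beyond the scatter. Compound 4 is expected to give about 50%, within a range from 30% to 70%.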

Compound 4, largest response reached (reported as efficacy), in percent of the reference or control that the assay uses: 50%
Beside the measured number, compound 4's estimate shows no gap at the digits printed, and the stated range covers the measured number.
By their numbers in this assay, from the lowest: compound 3; then compounds 1, 2 and 4 (each within the scatter of the next).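

At this position, this assay gives the same picture for a much larger group as for a small one: with phenyl in place of methyl on a saturated chain carbon, two bonds along the chain from two aromatic carbons, the result is no change at the digits printed from compound 2 to compound 4 (within the scatter). Set against the core of compound 1, benzyl in place of hydrogen on the saturated chain carbon bound to two aromatic carbons gives no change at the digits printed from compound 1 to compound 4 (within the scatter), so the added six-membered aromatic ring leaves the maximal response where ethyl left it. Nothing available accounts for this flat result.

Going by these compounds, whether an amine, a hydroxyl or a carboxylic acid on this chain would hold the same number remains open. So does whether benzyl or ethyl here would behave alike on the benzylamino compound 3.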